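This account rests on a few compounds, and the source may have more. Where it says the series, first, only, none or still open, it means among the compounds named here.

Measured compounds in an ADME assay on HEL cells (Homo sapiens) for cytotoxicity; on this read-out higher numbers stand for lower toxicity in this test and lower numbers for higher toxicity in this test:

Compound 1, `O=c1ccn(CCCCCOc2ccccc2)c(=O)[nH]1`, gives a limit of the assay, > 100000 nM.
Compound 2, `Cc1cc(C)cc(OCCCCCn2ccc(=O)[nH]c2=O)c1`, likewise gives a limit, > 100000 nM.
Compound 3, `CC(C)(C)c1ccc(OCCCCCn2ccc(=O)[nH]c2=O)cc1`, gives a number, 40000 nM.

Among the measured compounds shown here, compound 3 is thus the only member of the series with a number in this assay; the other two values are limits, a situation summed up by the limit of > 100000 nM in this assay, at which 2 of the 3 values shown sit. For the measured compounds named here, the one step that has been measured leads into compound 3: an at least 2.5-fold lower number from compound 1 to compound 3 (0.39 log units; beyond the scatter).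

The next compound, compound 4, `CCCOC(=O)c1ccc(OCCCCCn2ccc(=O)[nH]c2=O)cc1`, is not yet measured. Its change from compound 3: propoxycarbonyl in place of tert-butyl on an aromatic carbon. Going by the values given here, the only measured step that bears on this place is the one from compound 1 to compound 3, which shows that putting tert-butyl in at this position moved the number down, at least modestly. Taking tert-butyl out again is therefore expected to push the value back up toward the limit; what propoxycarbonyl adds on its own has no measured counterpart in this series, so the size of its contribution is open.

For compound 4 in this assay the estimate is 80000 nM, with a plausible range from 30000 nM to 200000 nM. This estimate corresponds to an expected step of a 2.0-fold higher number from compound 3 to compound 4 (0.30 log units; within the scatter), with a fair chance that the assay again reports only a limit.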

Compound 4, half-maximal cytotoxic concentration: > 100000 nM
Compound 4 ended at the assay's limit; the forecaster's own chance of this, stated with the estimate: 50%; at least 1.2-fold (0.09 log units) between middle value and limit.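

In this assay, this position, on an aromatic carbon and para to a large group, responds not just to whether a group is present but to which group it is: exchanging tert-butyl for propoxycarbonyl gives an at least 2.5-fold higher number from compound 3 to compound 4 (0.39 log units; beyond the scatter). The lower number seen with compound 3 therefore does not carry over to every group at this position, since the propoxycarbonyl group of compound 4 does not retain it, while the step from compound 1 to compound 4 cannot be read, as both ends are limits. Within the compounds shown, tert-butyl remains the only change that brings a value off the limit, and the series as a whole still sits mostly at that limit: the limit of > 100000 nM in this assay, at which 3 of the 4 values shown sit.

As far as these compounds go, it remains open whether a smaller group of the same kind, such as methoxycarbonyl, or a different one, such as an amine or a carboxylic acid, would give a number at this position in this assay. Also open, from the compounds shown here alone, are how isopropyl, as a smaller relative of tert-butyl, would behave and how far apart compound 1, compound 2 and compound 4 really lie, since their limits do not separate them.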